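Adding a Second Chlorine: Does Tolerance on Vero Cells Change?

The source may report more compounds than this note shows. Statements on the series, on what has been measured and on what is new or still open speak of the compounds shown alone.

Compound 1 (`NS(=O)(=O)c1ccc(N2N=C(c3ccc(Cl)cc3)CC2c2cn(-c3ccccc3)nc2-c2ccccc2)cc1`) was measured in an ADME assay on Vero cells (Chlorocebus sabaeus) for cytotoxicity, read by MTT assay, with a stated time of 72 h; a higher number here means that more compound is tolerated, a lower number that less compound is tolerated. In this assay compound 1 reaches only the limit of > 206000 nM, which marks the edge of what the measurement can report rather than a true number. Compound 2 (`COc1ccc(C2=NN(c3ccc(S(N)(=O)=O)cc3)C(c3cn(-c4ccccc4)nc3-c3ccccc3)C2)cc1`) carries a methoxy in place of the chloro on an aromatic carbon and gives 40200 nM in this assay, so that an at least 5.1-fold lower number from compound 1 to compound 2 (0.70 log units; beyond the scatter). Going by the values given here, that is the only measured step, and it concerns a different place on the molecule from the one that changes here.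

Compound 3 (`NS(=O)(=O)c1ccc(N2N=C(c3ccc(Cl)cc3)CC2c2cn(-c3ccccc3)nc2-c2ccc(Cl)cc2)cc1`) differs from compound 1 by chloro in place of hydrogen on an aromatic carbon. The rest of the molecule stays as it is. Among the compounds with values here, no measured step speaks to a hydrogen-to-chloro swap at this position, and compound 1 sits at the limit of > 206000 nM in this assay, at which 1 of the 2 values shown sits, so there is little room for the number to rise. The step is therefore expected to be an at least 1.0-fold lower number from compound 1 to compound 3 (0.01 log units; that floor lies within the scatter), within the scatter. Compound 3 is expected to give about 200000 nM in this assay, somewhere between 80000 nM and 400000 nM.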

Compound 3, half-maximal cytotoxic concentration: > 164000 nM
Compound 3 ended at the assay's limit; the forecaster's own chance of this, stated with the estimate: 60%; the middle value lies beyond the limit too.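

Compound 1 and compound 3 both end at a limit of this assay rather than at a true number, so no new step can be read between them. The compounds shown leave open how much of either compound the cells tolerate, and whether going from phenyl to 4-chlorophenyl changes that tolerance at all.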